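A few compounds are considered here, and "the series" means these few. Any claim that something is new, unique, unknown or untested is made for them only; others in the source may bear on it.

The compounds measured so far:
Compound 1, `O=C(Nc1cccc(-c2ccoc2)c1)C(Cl)Cl`, gives 37600 nM in a functional assay on NCI-H460 cells (Homo sapiens) for cytotoxicity, read by MTT assay, with a stated time of 68 h; a higher number here means a weaker inhibitor, a lower number a stronger inhibitor.
Compound 2, `COc1cccc(-c2cc(NC(=O)C(Cl)Cl)cc(-c3cccc(OC)c3)c2)c1`, gives > 30000 nM in this assay, which is a limit of the assay and not a number.

Within the data shown here, compound 1 stands as the only compound here with a reported number, and that number sits at the weak end of what this kind of assay can resolve. The second value, for compound 2, is recorded only as a limit (the limit of > 30000 nM in this assay, at which 1 of the 2 values shown sits), so it gives no point of comparison for the size of any step.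

The unmeasured compound 3, `O=C(Nc1cccc(-c2ccccc2)c1)C(Cl)Cl`, differs from compound 1 in one place: phenyl in place of furan-3-yl on an aromatic carbon. Both groups are flat aromatic rings of similar size, and the shared core, including the dichloroacetamide, stays unchanged.

Among the measured compounds shown here, with no measured step between two compounds to lean on, the expected step from compound 1 to compound 3 in this assay is a 1.1-fold higher number from compound 1 to compound 3 (0.03 log units; within the scatter), which amounts to none beyond the usual scatter. Compound 3 is therefore expected to give about 40000 nM in this assay, with a range from 15000 nM to 110000 nM.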

Compound 3, half-maximal inhibitory concentration: 20200 nM
Compound 3: middle estimate off by 2.0-fold (0.30 log units), on the high side, and the stated range covers the measured number.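

In this assay, the group on this aromatic carbon can be a six-membered aromatic ring of carbon only or a five-membered aromatic ring with a hetero atom: phenyl in place of furan-3-yl gives a 1.9-fold lower number from compound 1 to compound 3 (0.27 log units; within the scatter) and so no change that can be told from the usual scatter. The ring oxygen goes in this swap, and with it the hydrogen-bond acceptor counted on furan-3-yl, yet the assay does not separate the two compounds, so neither that atom nor the ring size shows up as mattering for this read-out. No measured property among the data shown bears on this result.

For compound 2, the value > 30000 nM is a limit of the assay and not a number. Going by these compounds, what an amine or a carboxylic acid in place of the ring would do to the number in this assay stays open, as does whether any group on this carbon can move it beyond the scatter.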